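A few compounds are considered here, and "the series" means these few. Any claim that something is new, unique, unknown or untested is made for them only; others in the source may bear on it.

Two compounds share one core, in which an amide joins a bicyclic amine to a six-membered aromatic ring of carbon only. Compound 1 `O=C(Nc1cc(C(F)(F)F)cc(C(F)(F)F)c1)C1NCCc2ccccc21` carries two trifluoromethyl groups on that ring, and compound 2 `O=C(Nc1cccc(O)c1)C1NCCc2ccccc21` carries a single hydroxy group. Both were tested in a functional assay on NUGC-3 cells (Homo sapiens) for inhibition, read by sulforhodamine B assay, with a stated time of 48 h; a lower number here means a stronger inhibitor of growth, a higher number a weaker inhibitor of growth. In this assay compound 1 gives only a limit, > 10000 nM. Compound 2 also gives only a limit in this assay, > 10000 nM. Compound 2 thus stands at the edge of what this assay can report, and it does not stand there alone: the limit of > 10000 nM in this assay, at which 2 of the 2 values shown sit. Compound 3 `O=C(Nc1cccc(C(F)(F)F)c1)C1NCCc2ccccc21` has not yet been measured. It differs from compound 2 in one place: trifluoromethyl in place of hydroxy on an aromatic carbon. Among the compounds with values here, no measured pair shows what this exchange does. Both compound 1 and compound 2 sit at the limit, so they point in no direction. Compound 3 is therefore expected to remain near that limit, with an expected step that the limit leaves unreadable from compound 2 to compound 3, nothing beyond the scatter. The estimate for compound 3 is 15000 nM, within a range from 5000 nM to 50000 nM.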

Compound 3, concentration for 50% growth inhibition: > 10000 nM
Compound 3: a limit, no number; the forecaster's own chance of this, stated with the estimate: 75%; the middle value lies beyond the limit too.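

Within the data shown here, no step from compound 1 or compound 2 to compound 3 can be read, because all three compounds stop at the same edge of this assay: the limit of > 10000 nM in this assay, at which 3 of the 3 values shown sit. The compounds shown leave open whether swapping groups on the aromatic ring changes growth inhibition at all, and how far apart their true values lie.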